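Chalcone Series: Acetamide to Thiophene Amide Step

A few compounds are considered here, and "the series" means these few. Any claim that something is new, unique, unknown or untested is made for them only; others in the source may bear on it.

Of the compounds shown here, two carry values so far. Compound 1 `O=C(/C=C/c1ccc([N+](=O)[O-])cc1)c1ccc(O)c(O)c1` gives 6100 nM in a functional assay on HCT-116 cells (Homo sapiens) for cytotoxicity, read by resazurin assay, with a stated time of 48 h; a lower number here means that less compound is needed, a higher number that more compound is needed for the effect. Compound 2 `CC(=O)Nc1ccc(C(=O)/C=C/c2cccc([N+](=O)[O-])c2)cc1` gives 1800 nM in this assay, the lower of the two numbers, and its gap to compound 1 lies beyond the scatter. Compound 3 `O=C(/C=C/c1cccc([N+](=O)[O-])c1)c1ccc(NC(=O)c2cccs2)cc1` has not yet been measured. It differs from compound 2 by thiophen-2-yl in place of methyl on a carbonyl carbon. Among the measured compounds shown here, no measured pair shows this change, so its size is unknown from the data. The step of a 1.2-fold lower number from compound 2 to compound 3 (0.08 log units; within the scatter) is expected to stay within the scatter, with no clear direction. The estimate for compound 3 is 1500 nM, within 500 nM to 4500 nM.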

Compound 3, half-maximal effective concentration: 2500 nM
Compound 3: middle estimate off by 1.7-fold (0.22 log units), on the low side; low and high end bracket the measured number.
By their numbers in this assay, from the lowest: compounds 2 and 3 (each within the scatter of the next); then compound 1.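

On the carbonyl carbon whose other neighbour is the amide-type nitrogen, thiophen-2-yl in place of methyl brings a 1.4-fold higher number from compound 2 to compound 3 (0.14 log units; within the scatter) in this assay. Among the compounds shown here, this is the first measured change at this place, and exchanging methyl for an aromatic ring does not move the number beyond the scatter. Nothing at hand bears on the cause of this result.

As far as these compounds go, whether a longer chain, such as butyl, or a phenyl ring behaves the same way on this carbonyl carbon stays open. The same holds for a chain ending in an amine or a carboxylic acid.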